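The source may report more compounds than this note shows. Statements on the series, on what has been measured and on what is new or still open speak of the compounds shown alone.

Measured compounds:
Compound 1 `CC(C)c1ccc(NC(=O)[C@H]2CN(C)C[C@@H]2c2ccc(/C=C/C(=O)Nc3ccccc3N)cc2)cc1` — 54 mL/min/kg
Compound 2 `CN1C[C@H](C(=O)Nc2ccc(C3CC3)cc2)[C@@H](c2ccc(/C=C/C(=O)Nc3ccccc3N)cc2)C1` — 60 mL/min/kg

In an in vitro ADME assay on microsomes from liver (Mus musculus) for pharmacokinetics, read by LC-MS, with a stated time of 10 min, tested at 1 uM (a higher number here means faster removal of the compound, a lower number slower removal), compound 2 gives the highest of the two numbers, though the step of a 1.1-fold higher number from compound 1 to compound 2 (0.05 log units; within the scatter) lies within the scatter, so the two compounds cannot be ordered. Compound 3 `CN1C[C@H](C(=O)Nc2ccc(Cl)cc2F)[C@@H](c2ccc(/C=C/C(=O)Nc3ccccc3N)cc2)C1` has not yet been measured. It differs from compound 2 in one place: 4-chloro-2-fluorophenyl in place of 4-cyclopropylphenyl on an amide-type nitrogen. Going by the values given here, the only measured step, the exchange of isopropyl for cyclopropyl on an aromatic carbon, is not the same change and was itself small. Among the compounds with values here, no measured step bears directly on an exchange of a 4-cyclopropylphenyl for a 4-chloro-2-fluorophenyl, so the expectation rests on compound 2 alone. Compound 3 is therefore expected to sit near compound 2, with a step of a 1.2-fold lower number from compound 2 to compound 3 (0.08 log units; within the scatter) that is not expected to exceed the scatter. The estimate for compound 3 in this assay is 50 mL/min/kg, within a range from 27 mL/min/kg to 92 mL/min/kg.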

Compound 3, clearance: 43 mL/min/kg
Compound 3: the middle estimate sits 1.2-fold (0.07 log units) above what was measured; the measured number falls inside the stated range.
By their numbers in this assay, from the lowest: compounds 3, 1 and 2 (each within the scatter of the next).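

In this assay, 4-chloro-2-fluorophenyl in place of 4-cyclopropylphenyl on the amide-type nitrogen gives a 1.4-fold lower number from compound 2 to compound 3 (0.14 log units; within the scatter), and the same group in place of 4-isopropylphenyl gives a 1.3-fold lower number from compound 1 to compound 3 (0.10 log units; within the scatter). The earlier compounds had shown only one alkyl group exchanged for another on the aromatic ring; these steps show that this position also accepts the loss of the alkyl group and the entry of chlorine and fluorine without a change beyond the scatter. The data offer no explanation for this result.

The compounds shown do not separate the contribution of the chlorine from that of the fluorine, as both enter together. They also leave open whether a carboxylic acid or a primary amine on this phenyl ring would shift the clearance beyond the scatter.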